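The source may hold more compounds than are shown below. What is called first, only, known or untested is meant among the compounds shown, and "the series" means these compounds.

Of the compounds shown here, two have numbers so far. Compound 1 `O=C(O)CC/C=C\CC1COC(c2ccsc2)OC1c1cccnc1` carries a thiophen-3-yl on the acetal carbon of the shared core, and in a functional assay for inhibition, with Homo sapiens as the target (a higher number here means weaker binding, a lower number tighter binding), compound 1 gives 1580 nM. Compound 2 `COc1ccccc1OC(C)(C)C1OCC(C/C=C\CCC(=O)O)C(c2cccnc2)O1` instead carries a 2-methoxyphenoxy on the branched carbon attached to the acetal, and in this assay compound 2 gives 224 nM. For the measured compounds named here, compound 2 therefore stands at the lowest number of the two, and its gap to compound 1 lies beyond the usual scatter; no single-point step between the two is available, so only the two values themselves can be compared.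

Compound 3 `CC(C)(Sc1ccccc1)C1OCC(C/C=C\CCC(=O)O)C(c2cccnc2)O1` keeps the core and the acid-bearing chain of compound 2 and differs only in one group (phenylsulfanyl in place of 2-methoxyphenoxy on a saturated chain carbon bound to two saturated chain carbons and a saturated ring carbon). Nothing measured yet bears on an exchange of this kind within the series, so the expectation rests on compound 2 alone. The step from compound 2 to compound 3 in this assay is expected to be small, a 1.4-fold higher number from compound 2 to compound 3 (0.15 log units; within the scatter), toward a slightly higher number and not clearly beyond the scatter. For compound 3 in this assay the estimate is 320 nM, with a range from 100 nM to 1000 nM.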

Compound 3, dissociation constant: 200 nM
Beside the measured number, compound 3's estimate is 1.6-fold (0.20 log units) above it; measured number inside the range.
By their numbers in this assay, from the lowest: compounds 3 and 2 (each within the scatter of the next); then compound 1.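

At the saturated chain carbon bound to two saturated chain carbons and a saturated ring carbon, phenylsulfanyl in place of 2-methoxyphenoxy gives a 1.1-fold lower number from compound 2 to compound 3 (0.05 log units; within the scatter) in this assay, so going from 9 to 7 heavy atoms, from two oxygens to one sulfur, and from 2 hydrogen-bond acceptors to 1 produces no readable change at this position. On the saturated ring carbon, the group of 10 heavy atoms in place of the group of 5 heavy atoms gives a 7.9-fold lower number from compound 1 to compound 3 (0.90 log units; beyond the scatter), which lies beyond the scatter and is the first listed step of this size in the series. No measurement to hand accounts for either step.

The compounds shown leave open whether the step from compound 1 depends on the aromatic ring of the larger group or on the branched carbon that carries it, a question that a plain tert-butyl on the same ring carbon would address. As far as these compounds go, it also remains open how far this tolerance extends, for instance to a phenylsulfonyl, a benzyl or an amine-bearing phenyl group at the same place.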